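A few compounds are considered here, and "the series" means these few. Any claim that something is new, unique, unknown or untested is made for them only; others in the source may bear on it.

Of the compounds shown here, three that share one core have been tested in a functional assay on SMMC-7721 cells (Homo sapiens) for cytotoxicity, read by MTT assay, with a stated time of 72 h; a lower number here means a stronger inhibitor, a higher number a weaker inhibitor. Compound 1 `CC(C)=C1C(=O)N(c2ccc(Cl)cc2)N(c2ccc(Cl)cc2)C1=O` gives 45600 nM. Compound 2 `COc1cc(C=C2C(=O)N(c3ccc(Cl)cc3)N(c3ccc(Cl)cc3)C2=O)ccc1O` gives 64900 nM, and these two values lie within the usual scatter of each other, so they cannot be ranked. Compound 3 `COc1ccc(C=C2C(=O)N(c3ccc(Cl)cc3)N(c3ccc(Cl)cc3)C2=O)cc1` gives > 128000 nM, which is a limit of the assay and not a number.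

The next compound to consider is compound 4 `CC(=C1C(=O)N(c2ccc(Cl)cc2)N(c2ccc(Cl)cc2)C1=O)c1ccc(O)cc1`, which has 4-hydroxyphenyl in place of methyl on a double-bonded chain carbon bound to a double-bonded ring carbon and a saturated chain carbon. Within the data shown here, no measured step makes this exact swap. Among the measured compounds shown here, the only measured step, an at least 1.9-fold higher number from compound 2 to compound 3 (0.29 log units; that floor lies within the scatter), replaces 4-hydroxy-3-methoxyphenyl with 4-methoxyphenyl, and it does not separate the pair beyond the scatter. Compound 2 is the closest guide, since it also has a hydroxy-bearing ring on a double-bonded chain carbon, and it gives 64900 nM. A weak result for compound 4 could still end at the limit of > 128000 nM in this assay, at which 1 of the 3 values shown sits.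

In this assay the expected change is a 1.3-fold higher number from compound 1 to compound 4 (0.12 log units; within the scatter), so no step beyond the scatter is expected. For compound 4 the estimated value is 60000 nM, with an expected range from 25000 nM to 128000 nM.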

Compound 4, half-maximal inhibitory concentration: 57000 nM
Estimate against measurement, compound 4: 1.1-fold (0.02 log units) above; low and high end bracket the measured number.
By their numbers in this assay, from the lowest: compounds 1, 4 and 2 (each within the scatter of the next). At a limit, above all of these: compound 3.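

In this assay, placing 4-hydroxyphenyl in place of methyl on a double-bonded chain carbon bound to a double-bonded ring carbon and a saturated chain carbon gives a 1.3-fold higher number from compound 1 to compound 4 (0.10 log units; within the scatter), so the two numbers cannot be ranked and this position tolerates a far larger group, one that brings an aromatic ring and a hydroxy group, with no readable cost in this assay. Among these compounds, the earlier step compared only one ring-bearing compound with another, so this is the first direct comparison of a small methyl group with a ring at this position. Among the compounds shown here, compound 3 remains the only compound here at a limit of the assay, which is a limit and not a number: the limit of > 128000 nM in this assay, at which 1 of the 4 values shown sits.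

The compounds shown leave open whether a group of another kind at this position, such as an amine, a carboxylic acid or a longer chain in place of methyl, would move the number beyond the scatter. Also open, going by these compounds, is whether the hydroxy group of the 4-hydroxyphenyl matters at all, which a plain phenyl ring at the same position would help to settle.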